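From sec-butyl to cyclohexyl on the amide nitrogen

This account rests on a few compounds, and the source may have more. Where it says the series, first, only, none or still open, it means among the compounds named here.

Within the data shown here, in a functional assay on the whole organism with Mus musculus as the target (on this read-out higher numbers stand for an effect only at larger amounts of compound and lower numbers for an effect already at smaller amounts), compound 1 `O=C(/C=C/c1cccc(C(F)(F)F)c1)NCCO` gives 117 mg/kg, the only plain number so far. Compound 2 `CN(C)C(=O)CCC(=O)c1cccc(C(F)(F)F)c1` is reported only as a limit, > 50 mg/kg. Compound 3 `CCC(C)NC(=O)CCC(=O)c1cccc(C(F)(F)F)c1` is also reported only as a limit, > 200 mg/kg, so its position is bounded on one side and no exact value is available.

The next change leads to compound 4 `O=C(CCC(=O)c1cccc(C(F)(F)F)c1)NC1CCCCC1`, with cyclohexyl in place of sec-butyl on an amide-type nitrogen. Among the measured compounds shown here, the one measured step that bears on this change is a step that the two limits leave unreadable from compound 2 to compound 3, and it offers no size to carry over. No step beyond the scatter can therefore be argued for in this assay, and no direction is expected. The expectation rests on compound 3, whose limit is > 200 mg/kg. Another report as a limit would not be surprising. The expected change is a number no higher from compound 3 to compound 4 (the limit leaves the size open). The estimate for compound 4 is 200 mg/kg, with an expected range of 90 mg/kg to 450 mg/kg.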

Compound 4, dose for half-maximal effect: > 200 mg/kg
Compound 4: only a limit was reported (the forecaster's own chance of this, stated with the estimate: 60%); the middle value sits exactly at the limit.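

Compound 4, like compound 3 and compound 2, is reported only as a limit, so no step can be read among these compounds. The compounds shown leave open whether cyclohexyl and sec-butyl on the amide-type nitrogen differ at all in half-maximal dose.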